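The compounds below may be only part of what the source reports. "The series", "measured", "known", "first", "only" and "open" are said of these compounds alone.

Of the compounds shown here, three of one family have been measured in an ADME assay on K562 cells (Homo sapiens) for cytotoxicity, read by MTT assay, with a stated time of 24 h; a higher number here means that more compound is tolerated, a lower number that less compound is tolerated. Compound 1 `c1ccc(OC(CCn2ccnc2)c2ccccc2)cc1` gives 220000 nM, compound 2 `Clc1ccc(C(CCn2ccnc2)Oc2ccccc2)cc1` gives 186000 nM, and compound 3 `CC(C)c1ccc(OC(CCn2ccnc2)c2ccc(Cl)cc2)cc1` gives 138000 nM; all three values lie within the usual scatter of one another, so compound 2 stands on common ground with both of its relatives. Compound 4 `Clc1ccc(C(CCn2ccnc2)Oc2c(Cl)cccc2Cl)cc1` differs from compound 2 in one place: 2,6-dichlorophenyl in place of phenyl on an oxygen on a saturated carbon. Among the measured compounds shown here, two measured steps bear on this change. Chloro in place of hydrogen on an aromatic carbon gave a 1.2-fold lower number from compound 1 to compound 2 (0.07 log units; within the scatter), and isopropyl in place of hydrogen on an aromatic carbon gave a 1.3-fold lower number from compound 2 to compound 3 (0.13 log units; within the scatter). Since both additions to an aromatic ring stayed within the scatter, no step beyond the scatter is expected for a 1.2-fold lower number from compound 2 to compound 4 (0.09 log units; within the scatter). Compound 4 is therefore estimated at 150000 nM, with a range from 70000 nM to 320000 nM.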

Compound 4, half-maximal cytotoxic concentration: 135000 nM
Estimate against measurement, compound 4: 1.1-fold (0.05 log units) above, and the stated range covers the measured number.
By their numbers in this assay, from the lowest: compounds 4, 3, 2 and 1 (each within the scatter of the next).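

In this assay, 2,6-dichlorophenyl in place of phenyl on an oxygen on a saturated carbon gives a 1.4-fold lower number from compound 2 to compound 4 (0.14 log units; within the scatter), so this place takes two chlorine atoms entering together and the number stays within the scatter. Among the compounds shown here, the earlier steps each added only one group to an aromatic ring. Nothing available explains this result. Open, as far as these compounds go, is whether an amine or a carboxylic acid on this phenyl ring would also stay within the scatter, and whether a longer chain on the shared core would do the same.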